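The compounds below may be only part of what the source reports. "The series", "measured", "known", "first", "only" and "open" are said of these compounds alone.

Three ethers of the shared core have so far been measured in a functional assay on HCT-15 cells (Homo sapiens) for antiproliferative activity, read by sulforhodamine B assay; a lower number here means a stronger inhibitor of growth, a higher number a weaker inhibitor of growth. Compound 1 `O=C(/C=C/c1ccc(O)cc1)c1c(O)cccc1OCCC1CCCC1` gives 3310 nM, compound 2 `O=C(/C=C/c1ccc(O)cc1)c1c(O)cccc1OCC1CCCC1` gives 3410 nM, and compound 3 `CC(C)(C)CCOc1cccc(O)c1C(=O)/C=C/c1ccc(O)cc1` gives 3430 nM. Compound 3 holds the highest of the three numbers, yet its steps to the others stay within the scatter: a 1.0-fold higher number from compound 1 to compound 3 (0.02 log units; within the scatter) and a 1.0-fold higher number from compound 2 to compound 3 (0.00 log units; within the scatter). Compound 4 `CCC(CC)COc1cccc(O)c1C(=O)/C=C/c1ccc(O)cc1` differs from compound 3 by pentan-3-yl in place of neopentyl on a saturated chain carbon bound to an oxygen on an aromatic ring. The earlier exchanges of one saturated group for another at or near this position, a 1.0-fold higher number from compound 2 to compound 3 (0.00 log units; within the scatter) and a 1.0-fold higher number from compound 1 to compound 2 (0.01 log units; within the scatter), moved nothing beyond the scatter. No step beyond the scatter is therefore expected here either: a 1.0-fold lower number from compound 3 to compound 4 (0.00 log units; within the scatter). Compound 4 is estimated at 3400 nM, with a range of 1700 nM to 6800 nM.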

Compound 4, concentration for 50% growth inhibition: 3420 nM
Beside the measured number, compound 4's estimate is 1.0-fold (0.00 log units) below it; measured number inside the range.
By their numbers in this assay, from the lowest: compounds 1, 2, 4 and 3 (each within the scatter of the next).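

In this assay, neopentyl and pentan-3-yl, the same atoms joined differently, give no difference at this position (a 1.0-fold lower number from compound 3 to compound 4 (0.00 log units; within the scatter)). The open-chain pentan-3-yl also stands level with the ring-bearing groups (a 1.0-fold higher number from compound 2 to compound 4 (0.00 log units; within the scatter); a 1.0-fold higher number from compound 1 to compound 4 (0.01 log units; within the scatter)), so across these four compounds neither the branching pattern nor a cyclopentyl ring separates the numbers. No evidence bears on why these saturated groups give such similar numbers.

Open, from the compounds shown here alone, is whether an amine, a carboxylic acid or a longer chain on this oxygen would move the number beyond the scatter.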